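The compounds below may be only part of what the source reports. "The series", "measured", "known", "first", "only" and "open" are said of these compounds alone.

For the measured compounds named here, in a functional assay on MDA-MB-231 cells (Homo sapiens) for inhibition, read by MTT assay, with a stated time of 48 h (on this read-out higher numbers stand for weaker inhibition of growth and lower numbers for stronger inhibition of growth), compound 1 `S=C(Nc1ccc(Cl)cc1)Nc1ccc2ncnc(Nc3cccc(Br)c3)c2c1` gives 8200 nM, while compound 2 `Fc1ccc(NC(=S)Nc2ccc3ncnc(Nc4cccc(Br)c4)c3c2)cc1Cl` gives 300 nM, the lower of the two numbers so far. Compound 3 `FC(F)(F)c1cc(NC(=S)Nc2ccc3ncnc(Nc4cccc(Br)c4)c3c2)ccc1Cl` keeps the rest of compound 2 and carries 4-chloro-3-(trifluoromethyl)phenyl in place of 3-chloro-4-fluorophenyl on an amide-type nitrogen. Going by the values given here, only one measured step bears on this change: a 27-fold lower number from compound 1 to compound 2 (1.44 log units; beyond the scatter). It is large and occurs at the same place, so a change of this group can move the number far in this assay. Among the compounds with values here, it is a single step, however, and no measured compound carries the entering group, so neither size nor direction is secure. A moderate move is expected, with the estimated step being a 2.0-fold higher number from compound 2 to compound 3 (0.30 log units; within the scatter). The estimated value for compound 3 is 600 nM, with an expected range from 150 nM to 2500 nM.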

Compound 3, concentration for 50% growth inhibition: 1100 nM
For compound 3 the middle estimate is 1.8-fold (0.26 log units) below the measured one, within the range that was stated.
By their numbers in this assay, from the lowest: compound 2; then compound 3; then compound 1.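

In this assay, exchanging 3-chloro-4-fluorophenyl for 4-chloro-3-(trifluoromethyl)phenyl on the amide-type nitrogen gives a 3.7-fold higher number from compound 2 to compound 3 (0.56 log units; beyond the scatter) and so gives back part of the gain that compound 2 had shown at this place. Trifluoromethyl in place of hydrogen on an aromatic carbon of the ring in compound 1 still gives a 7.5-fold lower number from compound 1 to compound 3 (0.87 log units; beyond the scatter), which shows that a second group other than the one in compound 2 can also lower the number, though by less. No measurement at hand accounts for either step.

The compounds shown leave open how a methoxy group, a nitrile or a carboxylic acid on this phenyl ring would read. They also leave open whether these steps would hold with a carbonyl in place of the thiocarbonyl carbon's sulfur.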